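Moving the aryl group on the shared core once more

A few compounds are considered here, and "the series" means these few. Any claim that something is new, unique, unknown or untested is made for them only; others in the source may bear on it.

Of the compounds shown here, two have been measured in a functional assay on HCC827 cells (Homo sapiens) for inhibition, read by MTT assay, with a stated time of 48 h, tested at 10 uM; a higher number here means more inhibition at the concentration tested (going by the name of the read-out), a lower number less inhibition. Compound 1 `CCc1ccc(Nc2cc(NC(=O)Nc3cc(OC)cc(OC)c3)ncn2)cc1` gives 66.2%. Among the compounds with values here, compound 2 `COc1cc(NC(=O)Nc2cc(Nc3ccc(C)c(C)c3)ncn2)cc(OC)c1` gives 45.7%, the lower of the two numbers, and the only step measured so far is a number 20.5 percentage points lower from compound 1 to compound 2 (beyond the scatter). Compound 3 `COc1cc(NC(=O)Nc2cc(Nc3cccc(C(C)(C)C)c3)ncn2)cc(OC)c1` has not yet been measured; it differs from compound 2 in one place: 3-(tert-butyl)phenyl in place of 3,4-dimethylphenyl on a nitrogen on an aromatic ring. Within the data shown here, the one measured step concerns the same position and the same kind of group, a substituted phenyl on the nitrogen, and it was modest in size. Compound 3 brings a larger group to that position, and the step from compound 2 to compound 3 is therefore expected to be of a comparable modest size, with the direction uncertain, so that compound 3 is expected to give about 50%, within 30% to 70%. This is expected to mean a number 4.3 percentage points higher from compound 2 to compound 3 (within the scatter).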

Compound 3, a percentage reported as inhibition, at one concentration (the size of the read-out at that concentration, not a potency): 48.7%
Estimate against measurement, compound 3: 1.3 percentage points above, within the range that was stated.
By their numbers in this assay, from the lowest: compounds 2 and 3 (each within the scatter of the next); then compound 1.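

In this assay, putting 3-(tert-butyl)phenyl in place of 3,4-dimethylphenyl gives a number 3 percentage points higher from compound 2 to compound 3 (within the scatter) and shows that this position can take a group of 10 heavy atoms instead of 8 with no change beyond the scatter. Set against 4-ethylphenyl, the same group gives a number 17.5 percentage points lower from compound 1 to compound 3 (beyond the scatter) and so compound 1 now stands apart from two differently substituted phenyl groups, with the highest number of the three. No measurement is available to explain either step.

On these data alone, whether a longer chain in place of the ethyl of compound 1 would hold or raise the number remains open. So does the effect of an amine or a carboxylic acid on the phenyl ring at this position.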